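A sulfur-for-oxygen swap on a shared diamino core

The source may hold more compounds than are shown below. What is called first, only, known or untested is meant among the compounds shown, and "the series" means these compounds.

Compound 2 `Nc1cc(N)c2nc(-c3ccccc3)c(Oc3ccc(F)cc3)nc2c1` carries a 4-fluorophenoxy group on its shared core. In a functional assay on OVCAR-4 cells (Homo sapiens) for inhibition, read by sulforhodamine B assay, with a stated time of 48 h (on this read-out higher numbers stand for lower toxicity in this test and lower numbers for higher toxicity in this test), compound 2 reaches only a limit of the assay, < 100000 nM, so its true number is not known. Compound 1 `Nc1cc(N)c2nc(-c3ccccc3)c(Sc3ccc(Cl)c(Cl)c3)nc2c1` is a close relative. In this assay compound 1 likewise stops at a limit, < 100000 nM. Within the data shown here, the only measured step, a step that the two limits leave unreadable from compound 1 to compound 2, therefore gives neither a size nor a direction, and both values sit at the limit of < 100000 nM in this assay, at which 2 of the 2 values shown sit. Compound 3 `Nc1cc(N)c2nc(-c3ccccc3)c(Sc3ccc(F)cc3)nc2c1` differs from compound 2 by (4-fluorophenyl)sulfanyl in place of 4-fluorophenoxy on an aromatic carbon. Among the measured compounds shown here, no measured step bears on this change, so nothing argues for a move beyond the scatter, and the step from compound 2 to compound 3 is expected to be a step that the limit leaves unreadable from compound 2 to compound 3. Compound 3 is therefore estimated at 30000 nM, within a range from 3000 nM to 100000 nM, with a fair chance that it too is reported only as a limit.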

Compound 3, concentration lethal to 50% of the cells: < 100000 nM
Compound 3 ended at the assay's limit; the forecaster's own chance of this, stated with the estimate: 60%; the middle value is on the limit's open side.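

Compound 3 stops at a limit of the assay, as do compound 1 and compound 2, so no step among the three can be read: the limit of < 100000 nM in this assay, at which 3 of the 3 values shown sit.

The compounds shown leave open how far each true value lies from that limit, and whether the 4-fluorophenoxy, (4-fluorophenyl)sulfanyl and (3,4-dichlorophenyl)sulfanyl groups differ at all.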